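Widening the ring on the amide: cyclopropyl to cyclopentyl

A few compounds are considered here, and "the series" means these few. Any claim that something is new, unique, unknown or untested is made for them only; others in the source may bear on it.

Measured so far:
compound 1 `CC(C)C(=O)Nc1c(C(O)(C(F)(F)F)C(F)(F)F)ccc2ccccc12` gives 6630 nM
compound 2 `C/C=C/C(=O)Nc1c(C(O)(C(F)(F)F)C(F)(F)F)ccc2ccccc12` gives 72 nM
compound 3 `O=C(Nc1c(C(O)(C(F)(F)F)C(F)(F)F)ccc2ccccc12)C1CC1` gives 751 nM

In an assay on LtK cells with ATP-sensitive inward rectifier potassium channel 11 (Homo sapiens) as the target (a lower number here means that less compound is needed, a higher number that more compound is needed for the effect), compound 3 stands second highest of the three numbers. Its nearest neighbour is compound 1, reached by an 8.8-fold lower number from compound 1 to compound 3 (0.95 log units; beyond the scatter); its furthest is compound 2, as a 10-fold higher number from compound 2 to compound 3 (1.02 log units; beyond the scatter) shows. Compound 4 `O=C(Nc1c(C(O)(C(F)(F)F)C(F)(F)F)ccc2ccccc12)C1CCCC1` has not been measured yet. The change is cyclopentyl in place of cyclopropyl on a carbonyl carbon. Within the data shown here, no measured step covers this swap; the two steps that change the same position, an 8.8-fold lower number from compound 1 to compound 3 (0.95 log units; beyond the scatter) and a 10-fold higher number from compound 2 to compound 3 (1.02 log units; beyond the scatter), were modest to large, so a change of that order is possible in either direction. A saturated ring of the same kind is entering, so a step near or somewhat above compound 3 is expected, a 2.0-fold higher number from compound 3 to compound 4 (0.30 log units; within the scatter). Compound 4 is estimated at 1500 nM, between 300 nM and 8000 nM.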

Compound 4, half-maximal effective concentration: 495 nM
The estimate for compound 4 lay 3.0-fold (0.48 log units) above the measured number; the measured number falls inside the stated range.
By their numbers in this assay, from the lowest: compound 2; then compounds 4 and 3 (each within the scatter of the next); then compound 1.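

In this assay, enlarging the saturated ring on the carbonyl carbon makes no readable difference: a 1.5-fold lower number from compound 3 to compound 4 (0.18 log units; within the scatter), so cyclopropyl and cyclopentyl cannot be told apart here. The larger ring also behaves like the smaller one against the open-chain groups: isopropyl gives a clearly higher number, with a 13-fold lower number from compound 1 to compound 4 (1.13 log units; beyond the scatter), while prop-1-en-1-yl gives a clearly lower one, with a 6.9-fold higher number from compound 2 to compound 4 (0.84 log units; beyond the scatter). As far as these compounds go, whether a cyclohexyl ring, or a ring carrying an amine, would stay at this level or come closer to compound 2 remains open. Nothing available explains any of these steps.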